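Working notes: from compound 3 to compound 4

The source may report more compounds than this note shows. Statements on the series, on what has been measured and on what is new or still open speak of the compounds shown alone.

Values in a functional assay on Huh-5-2 cells (Homo sapiens), read by MTT assay; on this read-out lower numbers stand for higher toxicity in this test and higher numbers for lower toxicity in this test:
- compound 1 `O=C(O)c1ccc2c(c1)nc(-c1ccc(OCc3cc(C(=O)N4CCCCC4)ccc3-c3ccc(Cl)cc3)cc1F)n2C1CCCCC1` gives 24000 nM
- compound 2 `CC(=O)Nc1ccc(-c2ccc(Cl)cc2)c(COc2ccc(-c3nc4cc(C(=O)O)ccc4n3C3CCCCC3)c(F)c2)c1` gives 24000 nM
- compound 3 `CC(=O)N(C)c1ccc(-c2ccc(Cl)cc2)c(COc2ccc(-c3nc4cc(C(=O)O)ccc4n3C3CCCCC3)c(F)c2)c1` gives 26000 nM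

Compound 3 stands level with the other two compounds, as all three values lie within the scatter of one another. Compound 4 `CN(C)C(=O)Nc1ccc(-c2ccc(Cl)cc2)c(COc2ccc(-c3nc4cc(C(=O)O)ccc4n3C3CCCCC3)c(F)c2)c1` is still to be measured. It differs from compound 3 as follows: (dimethylcarbamoyl)amino in place of acetyl(methyl)amino on an aromatic carbon. The (dimethylcarbamoyl)amino group takes the place of acetyl(methyl)amino on an aromatic carbon, para to a 4-chlorophenyl group.

Within the data shown here, three measured steps bear on this change: no change at the digits printed from compound 1 to compound 2 (within the scatter), a 1.1-fold higher number from compound 1 to compound 3 (0.03 log units; within the scatter) and a 1.1-fold higher number from compound 2 to compound 3 (0.03 log units; within the scatter). Each stays within the scatter, although the first two exchange quite different groups. Among the measured compounds shown here, no measured compound carries the (dimethylcarbamoyl)amino group, so this remains an extrapolation.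

No shift beyond the scatter is expected in this assay, in either direction, and the estimate is a 1.0-fold lower number from compound 3 to compound 4 (0.02 log units; within the scatter). Compound 4 is expected at 25000 nM, with an estimated range from 14000 nM to 42000 nM.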

Compound 4, half-maximal cytotoxic concentration: 25000 nM
Compound 4: the middle estimate sits on the measured number at the digits printed, and the stated range covers the measured number.
By their numbers in this assay, from the lowest: compounds 1, 2, 4 and 3 (each within the scatter of the next).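

In this assay, placing (dimethylcarbamoyl)amino on this aromatic carbon, para to a 4-chlorophenyl group, gives a 1.0-fold lower number from compound 3 to compound 4 (0.02 log units; within the scatter), so the position also tolerates a group that carries a hydrogen-bond donor on the nitrogen and a second nitrogen. Exchanging methyl for dimethylamino on the carbonyl carbon gives a 1.0-fold higher number from compound 2 to compound 4 (0.02 log units; within the scatter), and exchanging (piperidin-1-yl)carbonyl for the new group gives a 1.0-fold higher number from compound 1 to compound 4 (0.02 log units; within the scatter). All four groups tried at this position therefore remain level in this assay, and nothing available accounts for this flat picture.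

Going by these compounds, whether the flat picture extends to a free amine or a longer alkyl chain at this position remains open. The compounds shown also leave open whether it holds when the 4-chlorophenyl group or the shared core changes.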